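The source may hold more compounds than are shown below. What is called first, only, known or untested is meant among the compounds shown, and "the series" means these compounds.

Measured compounds:
- compound 1, `CCCN(CCC)c1ccc(NC(=O)c2cc(Cl)ccc2O)c(Cl)c1`: 323000 nM
- compound 2, `CC(=O)Nc1ccc(NC(=O)c2cc(Cl)ccc2O)c(Cl)c1`: "not determined" (no result reported)
- compound 3, `O=C(Nc1ccc(NCCCO)cc1Cl)c1cc(Cl)ccc1O`: "not determined" (no result reported)

In an ADME assay on A549 cells (Homo sapiens) for cytotoxicity, read by LDH release, with a stated time of 15 h (on this read-out lower numbers stand for higher toxicity in this test and higher numbers for lower toxicity in this test), compound 1 gives 323000 nM, a weak cytotoxic effect. Among the measured compounds shown here, compound 2 and compound 3 were tested in the same series but carry no number, so compound 1 holds the only value and no step between measured compounds is available to set a scale.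

Compound 4, `CCCCCCC(C)Nc1ccc(NC(=O)c2cc(Cl)ccc2O)c(Cl)c1`, differs from compound 1 in one place: (1-methylheptyl)amino in place of dipropylamino on an aromatic carbon. The dipropylamino group leaves and a (1-methylheptyl)amino group enters on an aromatic carbon, meta to a chloro group and para to a large group.

For the measured compounds named here, with no comparable step on record, the step of a 1.3-fold lower number from compound 1 to compound 4 (0.11 log units; within the scatter) is expected to stay within the usual scatter, with at most a slight shift toward higher toxicity. Compound 4 is accordingly expected to give about 250000 nM in this assay, with a range from 100000 nM to 500000 nM.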

Compound 4, half-maximal cytotoxic concentration: 18600 nM
Compound 4: middle estimate off by 13-fold (1.13 log units), on the high side; measured number below the stated range.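

In this assay, the aromatic carbon carrying the amino substituent proves sensitive to change: (1-methylheptyl)amino in place of dipropylamino gives a 17-fold lower number from compound 1 to compound 4 (1.24 log units; beyond the scatter) toward higher toxicity in this test. Among the compounds shown here, the earlier compounds offered no step, so this is the first sign that a change at this position can move the read-out beyond the scatter. Nothing on hand explains the shift. As far as these compounds go, it remains open whether an unbranched octylamino group, a plain amine or a chain ending in a carboxylic acid would shift the number in the same direction.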